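Benzyl for cyclohexyl on the imidazole nitrogen of compound 3

This account rests on a few compounds, and the source may have more. Where it says the series, first, only, none or still open, it means among the compounds named here.

Measured compounds:
compound 1, `Brc1ccc(-c2cn3ccnc3c(-c3ccc4ncn(C5CCCCC5)c4c3)n2)cc1`: 15.5%
compound 2, `c1ccc(Cn2cnc3ccc(-c4nc(-c5cccc6ccccc56)cn5ccnc45)cc32)cc1`: 10.3%
compound 3, `c1cn2cc(-c3ccc4c(c3)ncn4C3CCCCC3)nc(-c3ccc4ncn(C5CCCCC5)c4c3)c2n1`: 18.4%

In a functional assay on SF-268 cells (Homo sapiens) for inhibition, read by sulforhodamine B assay, with a stated time of 48 h, tested at 10 uM (on this read-out lower numbers stand for less inhibition and higher numbers for more inhibition at the one concentration tested (going by the name of the read-out)), compound 3 gives 18.4%, the highest of the three numbers, yet the gap to compound 1 and the gap to compound 2 both lie within the scatter, so the three compounds are not separated by this assay. Compound 4, `c1ccc(Cn2cnc3ccc(-c4nc(-c5ccc6c(c5)ncn6C5CCCCC5)cn5ccnc45)cc32)cc1`, differs from compound 3 by benzyl in place of cyclohexyl on an aromatic nitrogen. Among the compounds with values here, no measured pair shows this change alone. Compound 2, which also carries a benzyl on that nitrogen, gives 10.3%, a number within the scatter of compound 3. The step of a number 4.4 percentage points lower from compound 3 to compound 4 (within the scatter) is therefore expected to be small, with no direction beyond the scatter. Compound 4 is estimated at 14%, between 4% and 25%.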

Compound 4, a percentage reported as inhibition, at one concentration (the size of the read-out at that concentration, not a potency): -0.11%
For compound 4 the middle estimate is 14.1 percentage points above the measured one, outside the stated range (below it).
By their numbers in this assay, from the lowest: compound 4; then compounds 2, 1 and 3 (each within the scatter of the next).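

In this assay, within the data shown here, benzyl in place of cyclohexyl on the aromatic nitrogen gives a number 18.5 percentage points lower from compound 3 to compound 4 (beyond the scatter), the only step in this set that lies beyond the scatter. This shows that the read-out responds to the group on this nitrogen, and that the small inhibition of compound 3 does not survive this exchange. Nothing measured here explains the step.

As far as these compounds go, only cyclohexyl and benzyl are compared at this position, so it remains open how a methyl, a phenethyl or a dimethylaminoethyl chain would read. From the compounds shown here alone, compound 4 also keeps its other cyclohexyl, and the effect of changing that group remains open too.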